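Series notes: the step from compound 3 to compound 4

The compounds below may be only part of what the source reports. "The series", "measured", "known", "first", "only" and "open" are said of these compounds alone.

Measured in a functional assay on the whole organism (strain albino) for inhibition, with Rattus norvegicus as the target, read by paw edema, with stated times of 30 min and 1 h, at a dose of 100 mg/kg by the oral route; a higher number here means more inhibition at the dose given (going by the name of the read-out), a lower number less inhibition:
compound 1, `COc1ccc(C2=NN(C(=O)CBr)C(c3ccco3)C2)cc1OC`: 38%
compound 2, `COc1ccc(C2=NN(C(=O)CBr)C(c3c(Cl)cccc3Cl)C2)cc1OC`: 48%
compound 3, `COc1ccc(C2=NN(C(=O)CO[N+](=O)[O-])C(c3ccco3)C2)cc1OC`: 32%

Compound 3 gives the lowest of the three numbers in this assay. Its nearest neighbour is compound 1, and the step of a number 6 percentage points lower from compound 1 to compound 3 (within the scatter) lies within the scatter, so the two cannot be ordered. Its gap to compound 2 lies beyond the scatter.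

Compound 4, `COc1ccc(C2=NN(C(=O)CO[N+](=O)[O-])C(c3c(Cl)cccc3Cl)C2)cc1OC`, is not yet measured. It differs from compound 3 in one place: 2,6-dichlorophenyl in place of furan-2-yl on a saturated ring carbon

Among the compounds with values here, one measured step bears on this change. It is the same replacement made on the bromo analogue: a number 10 percentage points higher from compound 1 to compound 2 (within the scatter). That step is within the scatter, so on the numbers shown this replacement has not produced a shift that can be told from repeat variation. Within the data shown here, nothing contradicts it, since only one pair carries the change.

Compound 4 is therefore expected to show a step of a number 10 percentage points higher from compound 3 to compound 4 (within the scatter) that echoes the measured replacement in size and direction and remains within the scatter. The estimate for compound 4 in this assay is 42%, with a range from 30% to 55%.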

Compound 4, a percentage reported as inhibition, in the whole organism at one dose (the size of the read-out at that dose, not a potency): 40%
The estimate for compound 4 lay 2 percentage points above the measured number; low and high end bracket the measured number.
By their numbers in this assay, from the lowest: compounds 3, 1, 4 and 2 (each within the scatter of the next, the first and the last beyond it).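

In this assay, the replacement of furan-2-yl by 2,6-dichlorophenyl on the saturated ring carbon now has a second reading on the nitrooxy side, a number 8 percentage points higher from compound 3 to compound 4 (within the scatter), and it agrees with the reading on the bromo side: the same change on two cores in this assay, a number 10 percentage points higher (within the scatter) from compound 1 to compound 2 and a number 8 percentage points higher (within the scatter) from compound 3 to compound 4, 2 percentage points apart, within the scatter of two such steps

The exchange of bromo for nitrooxy on the chain carbon bound to the carbonyl carbon also gains a second reading, a number 8 percentage points lower from compound 2 to compound 4 (within the scatter), this time with 2,6-dichlorophenyl in place, and it agrees with the reading with furan-2-yl in place: the same change on two cores in this assay, a number 6 percentage points lower (within the scatter) from compound 1 to compound 3 and a number 8 percentage points lower (within the scatter) from compound 2 to compound 4, 2 percentage points apart, within the scatter of two such steps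

Each change therefore reads alike on both cores, and these four compounds give no sign that the size of one step depends on the other group, although every single step remains within the scatter.

Open, on these data alone, is whether an unsubstituted phenyl on the saturated ring carbon, or an amine or a hydroxyl on the chain carbon, would give a step that can be told from repeat variation. All values are read at one oral dose, so they give the size of the inhibition at that dose and leave potency open.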